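Bromo Keeps the Number; the Aryl Swap Is Tested Again

This account rests on a few compounds, and the source may have more. Where it says the series, first, only, none or still open, it means among the compounds named here.

Of the compounds shown here, three sharing one core have been tested in a toxicity assay on Vero cells (Chlorocebus sabaeus) for inhibition, read by MTT assay, with a stated time of 48 h; a higher number here means a weaker inhibitor, a lower number a stronger inhibitor. Compound 1 `O=C(N/N=C/c1c(-c2cc3ccccc3oc2=O)[nH]c2ccccc12)c1ccccc1Cl` reaches only a limit of the measurement, > 200000 nM. Compound 2 `O=C(N/N=C/c1c(-c2cc3ccccc3oc2=O)[nH]c2ccccc12)c1ccc(Cl)cc1F` likewise gives only a limit, > 200000 nM. Between them lies a step that the two limits leave unreadable from compound 1 to compound 2. Among the measured compounds shown here, compound 3 `O=C(N/N=C/c1c(-c2cc3ccc(Br)cc3oc2=O)[nH]c2ccccc12)c1ccccc1Cl` is the one compound with a real number: in this assay compound 3 gives 89300 nM. For the measured compounds named here, that is an at least 2.2-fold lower number from compound 1 to compound 3 (0.35 log units; beyond the scatter), the only readable step, since the limit of > 200000 nM in this assay, at which 2 of the 3 values shown sit, hides the size of the other.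

Compound 4 `O=C(N/N=C/c1c(-c2cc3ccc(Br)cc3oc2=O)[nH]c2ccccc12)c1ccc(Cl)cc1F` has not yet been measured. It differs from compound 3 by 4-chloro-2-fluorophenyl in place of 2-chlorophenyl on a carbonyl carbon. The same swap between compound 1 and compound 2 left no readable step, so it gives no guidance on direction or size. No change beyond the scatter is expected, and the expected step is no change at the digits printed from compound 3 to compound 4 (within the scatter). Compound 4 is therefore estimated at 89300 nM, with a range from 30000 nM to 200000 nM, while a fair chance remains that only a limit is recorded.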

Compound 4, half-maximal inhibitory concentration: < 25000 nM
Compound 4 was reported as a limit; the forecaster's own chance of this, stated with the estimate: 40%; at least 3.5-fold (0.55 log units) between middle value and limit.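

Among the compounds shown here, putting 4-chloro-2-fluorophenyl in place of 2-chlorophenyl on a carbonyl carbon gives, on the bromo-bearing core in this assay, an at least 3.5-fold lower number from compound 3 to compound 4 (0.55 log units; beyond the scatter), so this position can move the number, which the earlier compounds could not show. Bromo in place of hydrogen on an aromatic carbon also lowers the number with the new aryl group, giving an at least 8.0-fold lower number from compound 2 to compound 4 (0.90 log units; beyond the scatter). The bromo change has now pointed the same way twice: the same change on two cores in this assay, an at least 2.2-fold lower number (0.35 log units; beyond the scatter) from compound 1 to compound 3 and an at least 8.0-fold lower number (0.90 log units; beyond the scatter) from compound 2 to compound 4; the limit leaves it open whether they differ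

As far as these compounds go, the step between compound 1 and compound 2 cannot be read, so whether the aryl swap has any effect without bromo stays open: the limit of > 200000 nM in this assay, at which 2 of the 4 values shown sit. The true value of compound 4 also stays open, since only a limit is reported, as does the result of a carboxylic acid or an amine in place of the chlorine on that phenyl ring.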